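Two halogens join the phenyl of compound 3

The compounds below may be only part of what the source reports. "The series", "measured", "known", "first", "only" and "open" are said of these compounds alone.

Compound 3 `Cn1ccc2c(Oc3ccc(NC(=O)c4nn(-c5ccccc5)ccc4=O)cc3)ccnc21` was tested in a functional assay on MCF7 cells (Homo sapiens) for cytotoxicity, read by MTT assay, with a stated time of 72 h (a higher number here means a weaker inhibitor, a lower number a stronger inhibitor), where compound 3 gives 45200 nM. Among the numbers shown, that is the highest of two; compound 1 `O=C(Nc1ccc(Oc2ccnc3[nH]ccc23)cc1)c1nn(-c2ccc(Cl)c(F)c2)ccc1=O`, which differs in two places, gives 3110 nM, a markedly lower number. Compound 2 `Cn1ccc2c(Oc3ccc(NC(=O)c4nn(-c5ccc(Cl)cc5)ccc4=O)cc3)ccnc21` carries a chloro on its phenyl, and in this assay compound 2 reaches only the limit > 60000 nM, which is not a number but the edge of what the test reports (the limit of > 60000 nM in this assay, at which 1 of the 3 values shown sits). Going by the values given here, the one measured step that bears on the change here is an at least 1.3-fold lower number from compound 2 to compound 3 (0.12 log units; that floor lies within the scatter), so removing the chloro moved the number at most a little, within the scatter or toward a lower value. Compound 4 `Cn1ccc2c(Oc3ccc(NC(=O)c4nn(-c5ccc(Cl)c(F)c5)ccc4=O)cc3)ccnc21` differs from compound 3 by 4-chloro-3-fluorophenyl in place of phenyl on an aromatic nitrogen. Putting the chloro back, with a fluoro beside it, is expected to push the number up again or leave it where it is, giving a step of a 1.2-fold higher number from compound 3 to compound 4 (0.09 log units; within the scatter). Compound 4 is therefore estimated at 55000 nM, within a range from 20000 nM to 150000 nM.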

Compound 4, half-maximal inhibitory concentration: 16800 nM
For compound 4 the middle estimate is 3.3-fold (0.52 log units) above the measured one; measured number below the stated range.
By their numbers in this assay, from the lowest: compound 1; then compound 4; then compound 3. At a limit, above all of these: compound 2.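

In this assay, going by these compounds alone, the group on this aromatic nitrogen now clearly matters: 4-chloro-3-fluorophenyl in place of phenyl gives a 2.7-fold lower number from compound 3 to compound 4 (0.43 log units; beyond the scatter), the first change here that lies beyond the scatter. Adding the fluoro to the chlorophenyl gives an at least 3.5-fold lower number from compound 2 to compound 4 (0.55 log units; beyond the scatter), a step that is only a floor, as compound 2 stands at a limit: the limit of > 60000 nM in this assay, at which 1 of the 4 values shown sits. The methyl on the core also counts, now that both compounds carry the same 4-chloro-3-fluorophenyl: a 5.4-fold higher number from compound 1 to compound 4 (0.73 log units; beyond the scatter).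

Whether the fluoro would lower the number without the chloro stays open, as the compounds shown include no fluorophenyl lacking chlorine. Also open, going by these compounds, is whether a methoxy or a nitrile on this phenyl would lower the number as the two halogens do.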